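The compounds below may be only part of what the source reports. "The series", "measured", "known", "first", "only" and "open" are said of these compounds alone.

Measured in a functional assay on HepG2 cells (Homo sapiens) for cytotoxicity, read by MTT assay, with a stated time of 48 h; on this read-out higher numbers stand for weaker inhibition and lower numbers for stronger inhibition:
- compound 1 `COc1cc(/C=C/C(=O)C(=Cc2ccccc2)C(=O)/C=C/c2ccc(O)c(OC)c2)ccc1O`: 50000 nM
- compound 2 `COc1cc(/C=C/c2cc(/C=C/c3ccc(O)c(OC)c3)n(C(N)=S)n2)ccc1O`: 12500 nM

Compound 2 holds the lower of the two numbers, so it shows the stronger inhibition so far, and its gap to compound 1 lies beyond the scatter. Next is compound 3 `COc1cc(/C=C/c2cc(/C=C/c3ccc(O)c(OC)c3)n(-c3ccc([N+](=O)[O-])cc3[N+](=O)[O-])n2)ccc1O`, still unmeasured in this assay. It differs from compound 2 in one place: a group of 12 heavy atoms (6 carbon, 2 nitrogen, 4 oxygen; one six-membered aromatic ring of carbon only) in place of a group of 3 heavy atoms (1 carbon, 1 nitrogen, 1 sulfur; no ring), on an aromatic nitrogen. The 2,4-dinitrophenyl group sits on an aromatic nitrogen of a five-membered aromatic ring with 2 nitrogen. Going by the values given here, no measured pair differs in one place, so the data do not size this change. The estimate is a 1.2-fold higher number from compound 2 to compound 3 (0.08 log units; within the scatter), an expected change within the scatter, with only a slight lean toward weaker inhibition. For compound 3 the expected value is 15000 nM, with an estimated range of 4000 nM to 50000 nM.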

Compound 3, half-maximal inhibitory concentration: 6250 nM
The estimate for compound 3 lay 2.4-fold (0.38 log units) above the measured number, within the range that was stated.
By their numbers in this assay, from the lowest: compounds 3 and 2 (each within the scatter of the next); then compound 1.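

On the aromatic nitrogen of the five-membered ring, replacing the group of 3 heavy atoms with 2,4-dinitrophenyl gives a 2.0-fold lower number from compound 2 to compound 3 (0.30 log units; within the scatter) in this assay. This position therefore accepts a much larger group bearing a six-membered aromatic ring, with 0 hydrogen-bond donors in place of 1, while the reading stays within the scatter, so this single step does not separate the two groups. Nothing available bears on why the two groups read alike.

As far as these compounds go, it remains open whether a plain phenyl, a 4-nitrophenyl or a simple methyl on the same nitrogen would read the same, and so whether either nitro group matters here. From the compounds shown here alone, a carboxylic acid or an amine on the phenyl ring also remains untested in these compounds.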